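The source may report more compounds than this note shows. Statements on the series, on what has been measured and on what is new or still open speak of the compounds shown alone.

The measured compounds:

Compound 1 `Cn1ncnc1-c1cc(Oc2ccc(NC(=O)Nc3cccc(C(F)(F)F)c3)cc2F)ccn1`; in an ADME assay on WI-38 cells (Homo sapiens) for cytotoxicity, read by MTT assay, with a stated time of 72 h (a lower number here means a stronger inhibitor, a higher number a weaker inhibitor), compound 1 gives 22400 nM.
Compound 2 `Cn1cnnc1-c1cc(Oc2ccc(NC(=O)Nc3cccc(C(F)(F)F)c3)cc2F)ccn1`; in this assay compound 2 gives 12600 nM.
Compound 3 `CN(C)CCn1cnnc1-c1cc(Oc2ccc(NC(=O)Nc3ccccc3C(F)(F)F)cc2F)ccn1`; in this assay compound 3 reaches only a limit, > 50000 nM.

Compound 3 therefore stands at the edge of what this assay reports: the limit of > 50000 nM in this assay, at which 1 of the 3 values shown sits. Its number is a limit and not a measured value, so the step from it to compound 4 `CN(C)CCn1cnnc1-c1cc(Oc2ccc(NC(=O)Nc3ccc(Cl)cc3Cl)cc2F)ccn1` starts from a bound rather than a point.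

The change is 2,4-dichlorophenyl in place of 2-(trifluoromethyl)phenyl on an amide-type nitrogen. For the measured compounds named here, the only step measured between neighbouring compounds, a 1.8-fold lower number from compound 1 to compound 2 (0.25 log units; within the scatter), concerns the group on the aromatic carbon of the shared core, not the ring on the amide-type nitrogen, and it stays within the scatter. Going by the values given here, no measured step touches the aryl group that compound 4 exchanges, so there is nothing in the data to point to a move in either direction.

Compound 4 is thus expected to sit near the same bound, the estimated step being a number no higher from compound 3 to compound 4 (the limit leaves the size open). Compound 4 is estimated at 50000 nM in this assay, with a range from 18000 nM to 140000 nM, and a fair chance that only a limit is returned again.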

Compound 4, half-maximal inhibitory concentration: 10400 nM
Compound 4: the middle estimate sits 4.8-fold (0.68 log units) above what was measured; the whole stated range lies above it.
By their numbers in this assay, from the lowest: compounds 4, 2 and 1 (each within the scatter of the next, the first and the last beyond it). At a limit, above all of these: compound 3.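

Compound 4 shows that the aryl group on the amide-type nitrogen is a place where the number in this assay can move beyond the scatter: the exchange of 2-(trifluoromethyl)phenyl for 2,4-dichlorophenyl gives an at least 4.8-fold lower number from compound 3 to compound 4 (0.68 log units; beyond the scatter). For the compounds shown here, the earlier compounds could not show this, since their only readable step, a 1.8-fold lower number from compound 1 to compound 2 (0.25 log units; within the scatter), concerns the group on an aromatic carbon of the shared core and stays within the scatter. The size of the new step remains open at its upper end because compound 3 gives only a limit and not a measured value: the limit of > 50000 nM in this assay, at which 1 of the 4 values shown sits.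

The compounds shown leave open which part of the exchange carries the step, the loss of trifluoromethyl or the entry of the two chlorines, and whether a phenyl ring with a single chlorine, a methoxy group or a nitrile would give a number on the same side. They also leave open whether the same exchange would give a step of similar size on a core carrying a plain methyl group in place of the dimethylaminoethyl chain.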